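This account rests on a few compounds, and the source may have more. Where it says the series, first, only, none or still open, it means among the compounds named here.

Three compounds have been measured in a functional assay on MCF7 cells (Homo sapiens) for inhibition, read by MTT assay, with a stated time of 48 h; a higher number here means a weaker inhibitor, a lower number a stronger inhibitor:

Compound 1 `COc1ccc(/C=C/c2cc(OC)cc(OC)c2/C=C/C(=O)Nc2cc(OC)c(OC)c(OC)c2)cc1`: 7010 nM
Compound 2 `COc1ccc(/C=C/c2cc(OC)cc(OC)c2/C=C/C(=O)NC2CC2)cc1`: 3940 nM
Compound 3 `CCCCCN(CCCCC)C(=O)/C=C/c1c(/C=C/c2ccc(OC)cc2)cc(OC)cc1OC`: 6130 nM

Compound 1 carries the highest number of the three, but the gaps are small: a 1.8-fold lower number from compound 1 to compound 2 (0.25 log units; within the scatter), and the values of compound 1 and compound 3 sit within the scatter of each other. Compound 4 `CCCCCCNC(=O)/C=C/c1c(/C=C/c2ccc(OC)cc2)cc(OC)cc1OC` differs from compound 1 in one place: hexyl in place of 3,4,5-trimethoxyphenyl on an amide-type nitrogen. For the measured compounds named here, the steps that bear on this both change the group on the same amide-type nitrogen, and both stayed within the scatter: a 1.8-fold lower number from compound 1 to compound 2 (0.25 log units; within the scatter) and a 1.6-fold higher number from compound 2 to compound 3 (0.19 log units; within the scatter). No step beyond the scatter is therefore expected in this assay, in either direction. Compound 4 is estimated at 5500 nM, between 2500 nM and 12000 nM, which would mean a 1.3-fold lower number from compound 1 to compound 4 (0.11 log units; within the scatter).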

Compound 4, half-maximal inhibitory concentration: 5530 nM
For compound 4 the middle estimate is 1.0-fold (0.00 log units) below the measured one, within the range that was stated.
By their numbers in this assay, from the lowest: compounds 2, 4, 3 and 1 (each within the scatter of the next).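

In this assay, a hexyl chain, with no ring and no hydrogen-bond acceptors, replaces the 3,4,5-trimethoxyphenyl on the amide-type nitrogen, and the number barely moves (a 1.3-fold lower number from compound 1 to compound 4 (0.10 log units; within the scatter)). Hexyl also stays level with the other two groups (a 1.4-fold higher number from compound 2 to compound 4 (0.15 log units; within the scatter); a 1.1-fold lower number from compound 3 to compound 4 (0.04 log units; within the scatter)), so across these four compounds, ring or open chain on this nitrogen makes no difference beyond the scatter. Nothing available explains this flat result. Still open, going by these compounds, is whether a chain ending in an amine or a carboxylic acid on this nitrogen would step beyond the scatter.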